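This account rests on a few compounds, and the source may have more. Where it says the series, first, only, none or still open, it means among the compounds named here.

In an ADME assay on HEK293 cells (Homo sapiens) for cytotoxicity, read by resazurin assay, with a stated time of 24 h (a higher number here means that more compound is tolerated, a lower number that less compound is tolerated), the measured compounds stand as follows:

Compound 1 `Cc1cc(O)c(C(=O)O)c(C=Cc2ccc3ccccc3c2)c1` gives 52000 nM in this assay.
Compound 3 `COc1cc(O)c(C(=O)O)c(CCc2ccc3ccccc3c2)c1` gives 65000 nM in this assay.
Compound 2 `COc1cccc(C=Cc2ccc3ccccc3c2)c1C(=O)O` reaches only a limit of this assay, > 100000 nM.

Compound 2 therefore stands at the limit of > 100000 nM in this assay, at which 1 of the 3 values shown sits, and carries no number of its own, so it cannot be ordered against compound 1 or compound 3. Compound 4 `O=C(O)c1c(O)cccc1C=Cc1ccc2ccccc2c1`, not yet measured, differs from compound 2 by hydrogen in place of methyl on an oxygen on an aromatic ring. Among the measured compounds shown here, no measured step of this kind exists here; the two hydroxy-bearing compounds, compound 1 and compound 3, sit below the limit, so a modest move downward is expected, but a result at the limit again is also likely. Compound 4 is estimated at 70000 nM, with a range from 30000 nM to 160000 nM, which would mean an expected step of an at least 1.4-fold lower number from compound 2 to compound 4 (0.15 log units; that floor lies within the scatter).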

Compound 4, half-maximal cytotoxic concentration: 97000 nM
The estimate for compound 4 lay 1.4-fold (0.14 log units) below the measured number, within the range that was stated.
By their numbers in this assay, from the lowest: compounds 1, 3 and 4 (each within the scatter of the next). At a limit, above all of these: compound 2.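

In this assay, the change from methoxy to hydroxy now has a reading: an at least 1.0-fold lower number from compound 2 to compound 4 (0.01 log units; that floor lies within the scatter). From the compounds shown here alone, its true size stays unknown, since compound 2 has a limit and not a number: the limit of > 100000 nM in this assay, at which 1 of the 4 values shown sits. Hydrogen in place of methyl on an aromatic carbon gives a 1.9-fold higher number from compound 1 to compound 4 (0.27 log units; within the scatter), so removing this methyl shows no change beyond the scatter.

The compounds shown leave open how far compound 2 truly lies from compound 4. They also leave open whether a longer chain on that oxygen, or an amine in its place, would move the number beyond the scatter.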